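Methyl for hydrogen on the chain at the aromatic nitrogen

The source may hold more compounds than are shown below. What is called first, only, known or untested is meant among the compounds shown, and "the series" means these compounds.

In a functional assay on BT-549 cells (Homo sapiens) for cytotoxicity, read by MTT assay, with a stated time of 48 h (a higher number here means a weaker inhibitor, a lower number a stronger inhibitor), compound 1 `CCn1c(/C=C2/C(=O)Nc3ccc(F)cc32)nc2ccccc21` gives a value that is only a limit of the assay, > 50000 nM. Compound 2 `CC(C)n1c(/C=C2/C(=O)Nc3ccc(F)cc32)nc2ccccc21` gives 26700 nM in this assay. The change between them is methyl in place of hydrogen on a saturated chain carbon bound to an aromatic nitrogen and a saturated chain carbon, and it made an at least 1.8-fold lower number from compound 1 to compound 2 (0.27 log units; that floor lies within the scatter); that the floor of this step sits at the limit rests on (the limit of > 50000 nM in this assay, at which 1 of the 3 values shown sits). Compound 3 `Cn1c(/C=C2/C(=O)Nc3ccc(Cl)cc32)nc2ccccc21` carries a different core; how the two cores differ is not broken down here. In this assay compound 3 gives 39100 nM. Compound 4 `CCn1c(/C=C2/C(=O)Nc3ccc(Cl)cc32)nc2ccccc21` is still to be measured; it differs from compound 3 by methyl in place of hydrogen on a saturated chain carbon bound to an aromatic nitrogen. This is the same kind of change as that made between compound 1 and compound 2, though the place is not the same: here the carbon is bound to an aromatic nitrogen, there to an aromatic nitrogen and a saturated chain carbon. The step is expected to be a 1.5-fold lower number from compound 3 to compound 4 (0.18 log units; within the scatter), resting on the size of an at least 1.8-fold lower number from compound 1 to compound 2 (0.27 log units; that floor lies within the scatter). Compound 4 is estimated at 26000 nM, between 11000 nM and 60000 nM.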

Compound 4, half-maximal inhibitory concentration: > 50000 nM
Compound 4: only a limit was reported; the forecaster's own chance of this, stated with the estimate: 20%; middle value at least 1.9-fold (0.28 log units) away from the limit.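

In this assay, methyl in place of hydrogen on a saturated chain carbon bound to an aromatic nitrogen gave an at least 1.2-fold higher number from compound 3 to compound 4 (0.10 log units; that floor lies within the scatter). Set beside the earlier step, this does not show that the change carries a size from one core to the other, nor does it show that the two cores respond differently: the same change on two cores in this assay, an at least 1.8-fold lower number (0.27 log units; that floor lies within the scatter) from compound 1 to compound 2 and an at least 1.2-fold higher number (0.10 log units; that floor lies within the scatter) from compound 3 to compound 4; the limit leaves it open whether they differ. Neither step has a measured size, and the step of chloro in place of fluoro between compound 1 and compound 4 cannot be read at all: the limit of > 50000 nM in this assay, at which 2 of the 4 values shown sit.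

On these data alone, it remains open whether a longer chain such as propyl on the aromatic nitrogen, or an amine or a carboxylic acid carried on that chain, would give a value off the limit in this assay. As far as these compounds go, it also remains open how the methyl change reads on either core when both members of a pair give numbers rather than limits.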